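The source may report more compounds than this note shows. Statements on the series, on what has been measured and on what is new or still open speak of the compounds shown alone.

Compound 2, `O=C(Nc1ccc(Cl)c(-c2nnc3c(Cl)cccn23)c1)c1ccon1`, is one of two analogues that share a core in which an amide joins a chlorinated aniline to a fused heteroaromatic fragment. In a functional assay on MDA-MB-231 cells (Homo sapiens) for antiproliferative activity, read by MTT assay, with stated times of 72 h and 4 h (on this read-out lower numbers stand for stronger inhibition and higher numbers for weaker inhibition), compound 2 gives only a limit of the assay, > 100000 nM. Its neighbour compound 1, `Cc1cc(Cl)ccc1C(=O)Nc1ccc(Cl)c(-c2nnc3c(Cl)cccn23)c1`, carries a 4-chloro-2-methylphenyl group on the carbonyl carbon where compound 2 carries 1,2-oxazol-3-yl. In this assay compound 1 likewise gives only a limit, > 100000 nM. The step that the two limits leave unreadable from compound 1 to compound 2 therefore cannot be read, since (the limit of > 100000 nM in this assay, at which 2 of the 2 values shown sit). Compound 3, `CS(=O)(=O)c1cccc(C(=O)Nc2ccc(Cl)c(-c3nnc4c(Cl)cccn34)c2)c1`, differs from compound 2 by 3-(methylsulfonyl)phenyl in place of 1,2-oxazol-3-yl on a carbonyl carbon. Among the measured compounds shown here, no measured step bears readably on this change: the only recorded step shows that a 4-chloro-2-methylphenyl group and a 1,2-oxazol-3-yl group at this carbonyl carbon both leave the inhibition beyond the limit of this assay, and a 3-(methylsulfonyl)phenyl group has no counterpart among the measured compounds. The expectation for compound 3 is accordingly another limit rather than a readable step in this assay, a number no higher from compound 2 to compound 3 (the limit leaves the size open). Compound 3 is estimated at 100000 nM, within a range of 30000 nM to 300000 nM.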

Compound 3, half-maximal inhibitory concentration: > 100000 nM
Compound 3: no number, only a limit; the forecaster's own chance of this, stated with the estimate: 80%; the middle value lies on the limit itself.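

Compound 3, like compound 1 and compound 2, gives only a limit in this assay, so no new step among these three compounds can be read: the limit of > 100000 nM in this assay, at which 3 of the 3 values shown sit.

The compounds shown leave open how far apart compound 1, compound 2 and compound 3 actually lie, and whether any group on this carbonyl carbon gives a readable value in this assay.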